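Swapping fluoro for bromo on the shared core

This account rests on a few compounds, and the source may have more. Where it says the series, first, only, none or still open, it means among the compounds named here.

Three compounds share one core and differ only in a single group on an aromatic carbon. In an assay on isolated protein for inhibition of tyrosine-protein kinase receptor UFO (Homo sapiens), read by FRET and Z'-LYTE, with a stated time of 1.5 h (on this read-out higher numbers stand for weaker inhibition and lower numbers for stronger inhibition), compound 1 `Cc1c(C(=O)Nc2ccc(Oc3ncnc4[nH]cc(-c5ccccc5)c34)c(F)c2)c(=O)c2ccccc2n1C` gives > 10000 nM, which is a limit of the assay rather than a number. Compound 2 `Cc1c(C(=O)Nc2ccc(Oc3ncnc4[nH]cc(-c5ccccc5)c34)c(F)c2)c(=O)c2cc(Cl)ccc2n1C` gives 1890 nM in this assay. Compound 3 `Cc1c(C(=O)Nc2ccc(Oc3ncnc4[nH]cc(-c5ccccc5)c34)c(F)c2)c(=O)c2cc(F)ccc2n1C`, the starting point here, gives > 10000 nM, and this too is a limit. Two of the three values therefore sit at the same limit (the limit of > 10000 nM in this assay, at which 2 of the 3 values shown sit), so compound 3 stands together with compound 1 at the weak end of what has been measured. Compound 4 `Cc1c(C(=O)Nc2ccc(Oc3ncnc4[nH]cc(-c5ccccc5)c34)c(F)c2)c(=O)c2cc(Br)ccc2n1C` carries the change (bromo in place of fluoro on an aromatic carbon). Among the compounds with values here, two measured steps bear on it: an at least 5.2-fold lower number from compound 1 to compound 2 (0.72 log units; beyond the scatter) and an at least 5.2-fold higher number from compound 2 to compound 3 (0.72 log units; beyond the scatter). Chloro thus shifted the number beyond the scatter in comparison with both hydrogen and fluoro, and bromo is expected to behave more like chloro than like fluoro. The expected step is an at least 6.6-fold lower number from compound 3 to compound 4 (0.82 log units; beyond the scatter), a downward one. Compound 4 is therefore estimated at 1500 nM, within the range 400 nM to 6000 nM.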

Compound 4, half-maximal inhibitory concentration: 3120 nM
Estimate against measurement, compound 4: 2.1-fold (0.32 log units) below; low and high end bracket the measured number.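

In this assay, bromo on this aromatic carbon gives an at least 3.2-fold lower number from compound 3 to compound 4 (0.50 log units; beyond the scatter) and an at least 3.2-fold lower number from compound 1 to compound 4 (0.50 log units; beyond the scatter), so the gain seen with chloro does not belong to chloro alone. Set against chloro, bromo gives a 1.7-fold higher number from compound 2 to compound 4 (0.22 log units; within the scatter), so these two groups cannot be told apart in this assay. The four compounds thus fall into two sets, chloro and bromo on one side and hydrogen and fluoro on the other, and the last two cannot be ordered against each other because both stop at a limit: the limit of > 10000 nM in this assay, at which 2 of the 4 values shown sit.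

Still open, from the compounds shown here alone, is whether a group other than a halogen, such as methoxy, a nitrile or an amine, would behave here as chloro and bromo do. Also open, going by these compounds, is whether chloro or bromo would give the same result on another carbon of this ring.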